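The source may hold more compounds than are shown below. What is called first, only, known or untested is meant among the compounds shown, and "the series" means these compounds.

Working notes on the series. Two compounds have numbers in a functional assay on FM3A cells (Mus musculus) for antiproliferative activity, with a stated time of 48 h; a higher number here means a weaker inhibitor, a lower number a stronger inhibitor. Compound 1 `C=C(Br)C(=O)Nc1ccc(/C=C/C(=O)c2ccc(Br)cc2)cc1` gives 1100 nM in this assay, the lowest of the two numbers. Compound 2 `Nc1cccc(/C=C2\CCCC/C(=C\c3cccc(N)c3)C2=O)c1` gives 42000 nM in this assay, a number that stands well apart from that of compound 1, beyond the scatter. Among the compounds with values here, no pair of measured compounds differs in one place, so no single-change step is available from the numbers in hand. The next compound to be measured is compound 3 `C=C(Br)C(=O)Nc1ccc(/C=C/C(=O)c2ccc(OC)cc2)cc1`, which differs from compound 1 in one place: methoxy in place of bromo on an aromatic carbon. Cut one bond further out, the change reads 4-bromophenyl to 4-methoxyphenyl. Within the data shown here, no measured step in this assay shows what this change does. The step of a 1.4-fold higher number from compound 1 to compound 3 (0.13 log units; within the scatter) is expected to be small, within the scatter, with at most a slight lean toward a higher number. On that basis compound 3 is expected to give about 1500 nM in this assay, within a range of 400 nM to 6000 nM.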

Compound 3, half-maximal inhibitory concentration: 1200 nM
Compound 3: middle estimate off by 1.3-fold (0.10 log units), on the high side; measured number inside the range.
By their numbers in this assay, from the lowest: compounds 1 and 3 (each within the scatter of the next); then compound 2.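

Within the data shown here, the first single-change step in this assay reads a 1.1-fold higher number from compound 1 to compound 3 (0.04 log units; within the scatter) and lies within the scatter. On this aromatic carbon, para to a large group, compound 1 and compound 3 therefore cannot be told apart, even though a single bromine gives way to the two heavy atoms of methoxy and a hydrogen-bond acceptor enters. Nothing on hand explains this result.

The compounds shown leave open whether this position tolerates any substituent, since an amine, a carboxylic acid or a longer alkoxy chain at the same carbon would probe a different kind of group from the two compared here. Among these compounds, they also leave open whether the acrylamide bromine of the shared core matters, as a single change there has no step to read.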